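Chloro Replaces Sulfamoyl on a Sulfonyl Hydrazide Inhibitor

This account rests on a few compounds, and the source may have more. Where it says the series, first, only, none or still open, it means among the compounds named here.

Compound 1 `Cc1cccc(NNS(=O)(=O)c2ccc(S(C)(=O)=O)cc2)c1` gives 43 nM in an assay for inhibition of Indoleamine 2,3-dioxygenase 1 (Homo sapiens), read by spectrophotometry, with stated times of 1 h and 4 h; on this read-out lower numbers stand for stronger inhibition and higher numbers for weaker inhibition.
Compound 2 `CC(=O)Nc1ccc(S(=O)(=O)NNc2ccccc2)cc1` gives 71 nM in this assay.
Compound 3 `CC(=O)Nc1ccc(S(=O)(=O)NNc2ccc(S(N)(=O)=O)cc2)cc1` gives 2480 nM in this assay.

Compound 3 has the highest number of the three, standing beyond the scatter from both compound 1 and compound 2. For the measured compounds named here, the only single-site step measured is a 35-fold higher number from compound 2 to compound 3 (1.54 log units; beyond the scatter), a large change. Compound 4 `CC(=O)Nc1ccc(S(=O)(=O)NNc2ccc(Cl)cc2)cc1` differs from compound 3 by chloro in place of sulfamoyl on an aromatic carbon, the chloro sitting para to a large group. Because a 35-fold higher number from compound 2 to compound 3 (1.54 log units; beyond the scatter) came with the sulfamoyl entering, its leaving is expected to undo most of that step; what chloro itself contributes is not known from these compounds. Compound 4 is therefore expected to land near compound 2, with a 31-fold lower number from compound 3 to compound 4 (1.49 log units; beyond the scatter). The estimate for compound 4 is 80 nM, within 25 nM to 250 nM.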

Compound 4, half-maximal inhibitory concentration: 155 nM
Compound 4: the middle estimate sits 1.9-fold (0.29 log units) below what was measured; the measured number falls inside the stated range.
By their numbers in this assay, from the lowest: compounds 1 and 2 (each within the scatter of the next); then compound 4; then compound 3.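

Chloro in place of sulfamoyl brings a 16-fold lower number from compound 3 to compound 4 (1.20 log units; beyond the scatter) and shows that the large rise in the number at this position is tied to sulfamoyl, not to any group placed there. Chloro in place of hydrogen still brings a 2.2-fold higher number from compound 2 to compound 4 (0.34 log units; beyond the scatter) so this position holds chloro somewhat less well than hydrogen. Nothing measured here explains the difference between these groups.

Going by these compounds, whether an amine, a methyl group or a carboxylic acid at this position would match hydrogen or improve on it stays open. So does whether these groups would rank the same way on the core of compound 1.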